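The source may report more compounds than this note shows. Statements on the series, on what has been measured and on what is new or still open speak of the compounds shown alone.

Working notes on the series. Among the measured compounds shown here, compound 1 `Clc1ccccc1-c1nc2ncccc2o1`, compound 2 `FC(F)(F)c1ccccc1-c1nc2ncccc2o1` and compound 3 `Cc1ccccc1-c1nc2ncccc2o1` share one core and differ only in the single group on the pendant six-membered aromatic ring of carbon only. In a functional assay on the whole organism for inhibition, with Rattus norvegicus as the target, at a dose of 30 mg/kg (on this read-out higher numbers stand for more inhibition at the one dose given (going by the name of the read-out) and lower numbers for less inhibition), compound 1 gives 38%, compound 2 gives 19% and compound 3 gives 0%. On these numbers compound 1 stands highest of the three: the exchange of chloro for trifluoromethyl gives a number 19 percentage points lower from compound 1 to compound 2 (beyond the scatter), the exchange for methyl gives a number 38 percentage points lower from compound 1 to compound 3 (beyond the scatter), and between the two replacements a number 19 percentage points lower from compound 2 to compound 3 (beyond the scatter).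

Compound 4 `Clc1cccc(Cl)c1-c1nc2ncccc2o1`, not yet measured, differs from compound 1 by chloro in place of hydrogen on an aromatic carbon. For the measured compounds named here, no measured step adds a group while the chloro of compound 1 is kept; the measured steps only exchange that chloro and each exchange lowers inhibition, the largest being a number 38 percentage points lower from compound 1 to compound 3 (beyond the scatter). They therefore bear on compound 4 only in showing that, of the three groups tried at that place, the number in this assay is highest with chloro. The second chloro is expected to leave inhibition near that of compound 1 or raise it somewhat, a step of a number 7 percentage points higher from compound 1 to compound 4 (within the scatter), not clearly beyond the scatter. Compound 4 is expected to give 45%, within 25% to 65%.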

Compound 4, a percentage reported as inhibition, in the whole organism at one dose (the size of the read-out at that dose, not a potency): 14%
Beside the measured number, compound 4's estimate is 31 percentage points above it; measured number outside the range, below it.
By their numbers in this assay, from the lowest: compound 3; then compounds 4 and 2 (each within the scatter of the next); then compound 1.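

Among the compounds shown here, this is the first step at a place on the pendant ring other than the one exchanged so far: in this assay, chloro in place of hydrogen, on an aromatic carbon ortho to a group of 9 heavy atoms and meta to a chloro group, gives a number 24 percentage points lower from compound 1 to compound 4 (beyond the scatter). The earlier compounds shown here showed only that chloro gave the highest number of the three groups tried at the first place; this step shows that the same group entering at the second place, with the first chloro kept, lowers inhibition beyond the scatter, so the result with chloro at one place does not carry over to the other. Nothing available on these compounds accounts for the size or the direction of this step.

As far as these compounds go, whether the loss follows chloro alone or any group at this place stays open, and fluoro, methoxy or an amine there, with the first chloro kept, would separate the two. From the compounds shown here alone, the read-out also gives the size of the effect at one dose only, so how this step would look across other doses remains open.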